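The source may report more compounds than this note shows. Statements on the series, on what has been measured and on what is new or still open speak of the compounds shown alone.

Compound 1 `Nc1nc(N)c2c(-c3cc4ccccc4o3)cn([C@@H]3O[C@H](CO)[C@@H](O)[C@H]3O)c2n1` and compound 2 `Cc1nc(N)c2c(-c3cc4ccccc4o3)cn([C@@H]3O[C@H](CO)[C@@H](O)[C@H]3O)c2n1` share one core and differ by methyl in place of amino on an aromatic carbon. In a functional assay on CEM-DNR-bulk cells (Homo sapiens), read by MTT assay, with a stated time of 72 h (on this read-out lower numbers stand for stronger inhibition and higher numbers for weaker inhibition), compound 1 gives only a limit, > 20000 nM. Compound 2 gives 6310 nM, the only true number among the three results shown. Compound 3 `C#Cc1cn([C@@H]2O[C@H](CO)[C@@H](O)[C@H]2O)c2nc(N)nc(OC)c12` likewise gives only a limit, > 20000 nM. Among the measured compounds shown here, the step of an at least 3.1-fold lower number from compound 1 to compound 2 (0.50 log units; beyond the scatter) is the single measured step, and its size is bounded by the limit of > 20000 nM in this assay, at which 2 of the 3 values shown sit. Compound 4 `Cc1nc(N)c2c(-c3ccco3)cn([C@@H]3O[C@H](CO)[C@@H](O)[C@H]3O)c2n1` differs from compound 2 by furan-2-yl in place of 1-benzofuran-2-yl on an aromatic carbon. For the measured compounds named here, no measured step touches the aryl group, so the expectation rests on compound 2 alone, with wide uncertainty. Compound 4 is expected to give 14000 nM, between 4000 nM and 40000 nM. The expected step of a 2.2-fold higher number from compound 2 to compound 4 (0.35 log units; beyond the scatter) is therefore a modest weakening.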

Compound 4, half-maximal inhibitory concentration: > 20000 nM
Compound 4: no number, only a limit; the forecaster's own chance of this, stated with the estimate: 40%; at least 1.4-fold (0.15 log units) between middle value and limit.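

Furan-2-yl in place of 1-benzofuran-2-yl on this aromatic carbon gives an at least 3.1-fold higher number from compound 2 to compound 4 (0.50 log units; beyond the scatter) and is the first measured step at the aryl group, so the six-membered aromatic ring of 1-benzofuran-2-yl counts for something here. In this assay compound 4 gives only a limit, > 20000 nM, and not a number. The step is therefore bounded and not sized: the limit of > 20000 nM in this assay, at which 3 of the 4 values shown sit.

As far as these compounds go, how phenyl or naphthalen-2-yl would read on this aromatic carbon stays open. So does the effect of ethyl in place of the methyl of compound 2.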